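The compounds below may be only part of what the source reports. "The series", "measured", "known", "first", "only" and "open" are said of these compounds alone.

Working notes on the series. Compound 1 `CCc1nnsc1CO/N=C/c1c(C)nn(C)c1Oc1ccccc1Cl` and compound 2 `CCc1nnsc1CO/N=C/c1c(C)nn(C)c1Oc1ccc(C)cc1` carry an ethyl chain together with a substituted phenyl on an oxygen on the aromatic ring, whereas compound 3 `Cc1nnsc1CO/N=C/c1c(C)nn(C)c1Cl` carries a methyl chain and a chlorine there. In a functional assay on SGC-7901 cells (Homo sapiens) for inhibition, read by MTT assay, with a stated time of 48 h (a higher number here means a weaker inhibitor, a lower number a stronger inhibitor), compound 1 gives 15800 nM and compound 2 gives 19800 nM; the step of a 1.3-fold higher number from compound 1 to compound 2 (0.10 log units; within the scatter) lies within the scatter. Compound 3 reaches only a limit in this assay, > 50000 nM, as recorded in the limit of > 50000 nM in this assay, at which 1 of the 3 values shown sits. Compound 4 `CCc1nnsc1CO/N=C/c1c(C)nn(C)c1Cl` differs from compound 3 by methyl in place of hydrogen on a saturated chain carbon bound to an aromatic carbon. Going by the values given here, the one measured step concerns the group on the oxygen, not the saturated chain carbon bound to an aromatic carbon, so no measured step bears on this change, and compound 3 offers only a limit as anchor. The expected step of a number no higher from compound 3 to compound 4 (the limit leaves the size open) is therefore none beyond the scatter. Compound 4 is expected to sit at or near the same limit, estimated at 50000 nM with a range from 20000 nM to 150000 nM.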

Compound 4, half-maximal inhibitory concentration: > 50000 nM
Compound 4: only a limit was reported (the forecaster's own chance of this, stated with the estimate: 55%); the middle value lies on the limit itself.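

With the ethyl chain held, the aromatic carbon of the shared core now has a measured reading in this assay: chloro in place of 2-chlorophenoxy gives an at least 3.1-fold higher number from compound 1 to compound 4 (0.50 log units; beyond the scatter) and chloro in place of 4-methylphenoxy gives an at least 2.5-fold higher number from compound 2 to compound 4 (0.40 log units; beyond the scatter). Compound 3 and compound 4 both stand at a limit, so methyl in place of hydrogen on the saturated chain carbon cannot be read, and the sizes above are only minimums: the limit of > 50000 nM in this assay, at which 2 of the 4 values shown sit. On these data alone, whether the ethyl chain matters with a phenoxy group present stays open. So does what an amine on that aromatic carbon, or a propyl chain in place of ethyl, would give.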